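Chain extension at the acid end of a diaryl pyridine core

A few compounds are considered here, and "the series" means these few. Any claim that something is new, unique, unknown or untested is made for them only; others in the source may bear on it.

Compound 1 `O=C(O)CCCOc1cc(-c2ccccc2)cc(-c2ccccc2)n1` carries a carboxy group on a short chain ether of the shared core. In an assay on cell membranes from spleen (Cavia porcellus) for binding affinity to leukotriene B4 receptor 1 (Homo sapiens) (a lower number here means a stronger inhibitor, a higher number a weaker inhibitor), compound 1 gives 300 nM, level with compound 3 `Cc1ccc(-c2cc(-c3ccccc3)cc(OCCCCCC(=O)O)n2)cc1`, which gives 300 nM; together these stand as the highest numbers of the three. Compound 2 `O=C(O)CCCCCOc1cc(-c2ccccc2)cc(-c2ccc(F)cc2)n1` gives 30 nM, the lowest number in this assay. Among the compounds with values here, the only single-point step in the set, a 10-fold higher number from compound 2 to compound 3 (1.00 log units; beyond the scatter), concerns a change on an aromatic carbon, not the acid chain, so it does not bear on the change now in view. Compound 4 `CC(C)(CCCCCCOc1cc(-c2ccccc2)cc(-c2ccccc2)n1)C(=O)O` differs from compound 1 by 4-carboxy-4-methylpentyl in place of carboxy on a saturated chain carbon, three bonds along the chain from an oxygen on an aromatic ring. Within the data shown here, no measured pair differs in that place alone; compound 2 differs from compound 1 in two places at once, so its lower number cannot be assigned to the chain. The step of a 2.5-fold lower number from compound 1 to compound 4 (0.40 log units; beyond the scatter) is therefore expected to be small and uncertain, in the direction of a lower number. Compound 4 is estimated at 120 nM, within a range from 25 nM to 600 nM.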

Compound 4, half-maximal inhibitory concentration: 22 nM
Estimate against measurement, compound 4: 5.5-fold (0.74 log units) above, and the stated range ends above it.
By their numbers in this assay, from the lowest: compounds 4 and 2 (each within the scatter of the next); then compounds 1 and 3 (each within the scatter of the next).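

Within the data shown here, with the acid chain as the only change, the step of a 14-fold lower number from compound 1 to compound 4 (1.13 log units; beyond the scatter) in this assay gives the first direct reading at this position. Among these compounds, it shows that the saturated chain carbon, three bonds along the chain from an oxygen on an aromatic ring, accepts 4-carboxy-4-methylpentyl in place of carboxy, and that this change alone moves the number by a large step, which the earlier compounds could not show. Nothing measured here accounts for the size of this step.

The change brings a longer chain and a branching methyl substitution together, so the compounds shown do not separate what each contributes. Going by these compounds, it also remains open how an unbranched chain of the same length, or a tetrazole in place of the carboxylic acid, would read on this core.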